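Adding One Carbon on the Ring Nitrogen

The compounds below may be only part of what the source reports. "The series", "measured", "known", "first", "only" and "open" are said of these compounds alone.

Among the compounds with values here, compound 1 `N#Cc1ccnc(Oc2nn(C3CCC3)c3ncnc(N)c23)c1` and compound 2 `Nc1ncnc2c1c(Oc1cc(C(F)(F)F)ccn1)nn2C1CC1` share a core but differ in more than one place, so no single step links them. In an ADME assay on microsomes from liver (Homo sapiens) for metabolic stability, read by LC-MS, using NADPH, with a stated time of 10 min, tested at 10 uM (a lower number here means that the compound disappears faster, a higher number that the compound lasts longer), compound 1 gives 2.35 h. For compound 2 this assay reports only a limit, > 2.41 h, and not a number (the limit of > 2.41 h in this assay, at which 1 of the 2 values shown sits). From the compounds shown here alone, compound 2 therefore stands at the edge of what this assay can report, and its exact half-life is unknown. Compound 3 `Nc1ncnc2c1c(Oc1cc(C(F)(F)F)ccn1)nn2CC1CC1` has not yet been tested. It differs from compound 2 by cyclopropylmethyl in place of cyclopropyl on an aromatic nitrogen. Within the data shown here, no measured pair shows such a change, so the expectation rests on compound 2 alone and on the fact that its reading already sits at the limit. The expected step is an at least 1.2-fold lower number from compound 2 to compound 3 (0.08 log units; that floor lies within the scatter), a shift no larger than the usual scatter. Compound 3 is estimated at 2 h, within a range from 1 h to 2.41 h.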

Compound 3, half-life: 1.87 h
For compound 3 the middle estimate is 1.1-fold (0.03 log units) above the measured one, within the range that was stated.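

Within the data shown here, this is the first measured pair for a change on this aromatic nitrogen: in this assay, cyclopropylmethyl in place of cyclopropyl gives an at least 1.2-fold lower number from compound 2 to compound 3 (0.11 log units; that floor lies within the scatter). Only that floor is known, and it does not show that the added carbon has any real effect on how long the compound lasts. Compound 3 has an actual reading of 1.87 h. The true size of the step stays unknown because compound 2 carries a limit and not a number: the limit of > 2.41 h in this assay, at which 1 of the 3 values shown sits.

The compounds shown leave open how a longer chain, or a chain ending in an amine, on this ring nitrogen would fare in this assay. They also leave open whether the same change would give a similar result with a nitrile in place of the trifluoromethyl group.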